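The compounds below may be only part of what the source reports. "The series", "measured", "known", "first", "only" and "open" are said of these compounds alone.

Compound 1, with the structure `COc1cc(C)cc(-c2c(-c3ccnc(-c4ccc(N(C)C)cc4)c3)cnn2CC#N)c1`, was examined in a functional assay on HCT-15 cells (Homo sapiens) for cytotoxicity, read by sulforhodamine B assay, with a stated time of 48 h, tested at 1 uM (a lower number here means a stronger effect, a higher number a weaker effect of the compound at the concentration tested), where compound 1 gives 9%. Two related compounds were measured alongside it. Among the measured compounds shown here, compound 2, with the structure `COc1cc(C)cc(-c2nn(CC#N)cc2-c2ccnc(-c3ccc(N(C)C)cc3)c2)c1`, gives -1% in this assay, a number that lies within the usual scatter of the one for compound 1. Compound 3, with the structure `Cc1cc(O)cc(-c2nn(CC#N)cc2-c2ccnc(-c3ccc(Oc4ccccc4)cc3)c2)c1`, gives -34%, which sits well beyond the scatter from the number for compound 1. Among the three numbers, the one for compound 1 is the highest, meaning the weakest effect at the tested concentration, although compound 2 cannot be told apart from it.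

The next compound, compound 4, has the structure `COc1cc(C)cc(-c2c(-c3ccnc(-c4ccc(C(C)=O)cc4)c3)cnn2CC#N)c1`. Its difference from compound 1 is a single one: acetyl in place of dimethylamino on an aromatic carbon. For the measured compounds named here, no measured pair of compounds shows what such a change does in this assay. Going by the values given here, since the three numbers so far are all low, the step from compound 1 to compound 4 is expected to be small and not beyond the scatter, roughly a number 7 percentage points lower from compound 1 to compound 4 (within the scatter). On that basis compound 4 is estimated to give about 2% in this assay, most likely falling between -25% and 25%.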

Compound 4, a percentage reported as activity, at one concentration (the size of the read-out at that concentration, not a potency): 12%
Estimate against measurement, compound 4: 10 percentage points below, within the range that was stated.
By their numbers in this assay, from the lowest: compound 3; then compounds 2, 1 and 4 (each within the scatter of the next, the first and the last beyond it).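

Until now, nothing showed what the group at this position does in this assay. The pair of compound 1 and compound 4 gives the first direct reading, and the step is a number 3 percentage points higher from compound 1 to compound 4 (within the scatter) and so shows no real change. Dimethylamino and acetyl each hold 3 heavy atoms and sit on the same aromatic carbon, para to a large group, yet one carries a nitrogen and the other a carbonyl, and at this single concentration that exchange cannot be told apart from repeat-to-repeat variation, a finding that rests on this one pair on the core of compound 1.

On these data alone, whether a primary amine, a carboxylic acid, a longer chain such as butyryl or a plain hydrogen in this place would also leave the number within the scatter remains open, as does whether the same exchange on the core of compound 2 would behave alike. Nothing among the data shown offers an explanation for why this exchange leaves the number within the scatter.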